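Pyrimidine in place of pyridine on the amine of compound 1

The source may hold more compounds than are shown below. What is called first, only, known or untested is meant among the compounds shown, and "the series" means these compounds.

Of the compounds shown here, three have been measured in a functional assay on CHO cells for antagonist activity at Orexin/Hypocretin receptor type 1 (Homo sapiens), read by FLIPR and calcium flux; a lower number here means a less potent compound, a higher number a more potent compound, by a factor of ten per unit of this negative logarithm. Compound 1 `Cc1cccc(NC[C@@H]2CC3(CC3)CN2C(=O)c2nc(C)sc2-c2ccccc2)n1` gives 7.3, the lowest of the three numbers. Compound 2 `O=C(c1ncccc1-c1ncccn1)N1CC2(CC2)C[C@H]1CNc1ccc(C(F)(F)F)cn1` gives 7.7, which stands above compound 1 by more than the scatter. Compound 3 `Cc1ccc(-c2nccs2)c(C(=O)N2CC3(CC3)C[C@H]2CNc2ccc(C(F)(F)F)cn2)n1` gives 8.6, which also stands above compound 1 by more than the scatter. For the measured compounds named here, no two measured compounds differ in a single place, so no single-point step can be read from the numbers themselves.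

Compound 4 `Cc1cc(C)nc(NC[C@@H]2CC3(CC3)CN2C(=O)c2nc(C)sc2-c2ccccc2)n1` is the next compound to be measured. It differs from compound 1 by 4,6-dimethylpyrimidin-2-yl in place of 6-methylpyridin-2-yl on an amine nitrogen. Going by the values given here, no measured pair shows this exchange, so the expectation rests on compound 1 alone and on the absence of any comparable step. The change is expected to move the number little, within or only just beyond the scatter, without a clear direction. For compound 4 the estimate in this assay is 7.4, with a range from 6.8 to 8. The step this estimate implies reads a number 0.10 log units higher from compound 1 to compound 4 (within the scatter).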

Compound 4, negative logarithm of the antagonist equilibrium constant: 7.5
Compound 4: the middle estimate sits 0.10 log units below what was measured, and the stated range covers the measured number.
By their numbers in this assay, from the lowest: compounds 1, 4 and 2 (each within the scatter of the next, the first and the last beyond it); then compound 3.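

At the amine nitrogen of the core of compound 1, 4,6-dimethylpyrimidin-2-yl in place of 6-methylpyridin-2-yl reads in this assay as a number 0.20 log units higher from compound 1 to compound 4 (within the scatter). This first single-place step in the series shows that this position takes a second ring nitrogen and an extra methyl together with no change beyond the scatter. No measurement bears on the reason for this result.

The two parts of the exchange arrive together, so their separate contributions cannot be read, and a pyrimidin-2-yl carrying no methyl, or one carrying a chlorine or a methoxy group, would be needed to separate them. Going by these compounds, whether the same exchange holds with the amide parts of compound 2 and compound 3 also stays open.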